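Acyl chain extension on the N-acylated benzylamine of compound 1

This account rests on a few compounds, and the source may have more. Where it says the series, first, only, none or still open, it means among the compounds named here.

Measured compounds:
compound 1 `COc1ccc(CN(C(C)=O)c2cc(OC)c(OC)c(OC)c2)cc1O` gives 79 nM
compound 2 `COc1ccc(CNc2cc(OC)c(OC)c(OC)c2)cc1` gives 11400 nM
compound 3 `COc1cc(NCc2cccc(O)c2)cc(OC)c1OC` gives 57600 nM

All three numbers come from a functional assay on MGC-803 cells (Homo sapiens) for inhibition, read by MTT assay, with a stated time of 48 h; on this read-out lower numbers stand for stronger inhibition and higher numbers for weaker inhibition. Compound 1 gives the lowest number of the three, and both gaps to it lie beyond the scatter: compound 2 stands well above it, and compound 3 stands further above still. Among the measured compounds shown here, compound 2 and compound 3 lack the acetyl group on the nitrogen that compound 1 carries, and they differ from compound 1 elsewhere as well, so no single step between measured compounds can be read from these values.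

Compound 4 `CCCCC(=O)N(Cc1ccc(OC)c(O)c1)c1cc(OC)c(OC)c(OC)c1` has not yet been measured in this assay. It differs from compound 1 in one place: propyl in place of hydrogen on a saturated chain carbon bound to a carbonyl carbon. Read one bond further out, the change is acetyl to butylcarbonyl.

For the measured compounds named here, nothing among the measured compounds shows what a longer acyl chain does here. The expectation for the step is that compound 4 stays close to compound 1, with a shift of a 1.9-fold higher number from compound 1 to compound 4 (0.28 log units; within the scatter) that may or may not exceed the scatter, more likely towards a somewhat higher number than a lower one. Compound 4 is therefore estimated at 150 nM, within a range from 40 nM to 600 nM.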

Compound 4, half-maximal inhibitory concentration: 66 nM
Compound 4: the middle estimate sits 2.3-fold (0.36 log units) above what was measured; low and high end bracket the measured number.
By their numbers in this assay, from the lowest: compounds 4 and 1 (each within the scatter of the next); then compound 2; then compound 3.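

In this assay, among the compounds shown here, the acyl chain gives the first single-place step: propyl in place of hydrogen on the saturated chain carbon bound to the carbonyl carbon, which turns acetyl into butylcarbonyl, gives a 1.2-fold lower number from compound 1 to compound 4 (0.08 log units; within the scatter). This position therefore accepts the added propyl without a shift beyond the scatter, so the two chain lengths cannot be told apart on this read-out. No available evidence accounts for this result.

Going by these compounds, whether the same holds for a longer chain such as octanoyl, or for a chain ending in an amine, a carboxylic acid or a phenyl ring, remains open, as two chain lengths define no trend. On these data alone, the contribution of the acyl group on the nitrogen itself also remains open: compound 2 and compound 3 lack it but differ from compound 1 elsewhere as well, so that step cannot be read.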